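Adding a Second Chloro to Compound 2

The compounds below may be only part of what the source reports. "The series", "measured", "known", "first", "only" and "open" are said of these compounds alone.

For the measured compounds named here, in an ADME assay on Caco-2 cells (Homo sapiens) for permeability, in the apical to basolateral direction, at pH 7.4 (a higher number here means that the compound crosses the layer faster, a lower number that the compound crosses the layer more slowly), compound 2, `O=C(N[C@H]1CN(S(=O)(=O)c2ccccc2)C[C@@H]1C(=O)N[C@H]1CCCNC1)c1cc(-c2ccccc2Cl)on1`, gives 0.31 10^-6 cm/s, the only actual number so far. Compound 1, `O=C(N[C@H]1CN(S(=O)(=O)c2ccccc2)C[C@@H]1C(=O)N[C@H]1CCCNC1)c1cc(-c2ccc(Cl)cc2)on1`, gives only a limit of the assay, < 0.01 10^-6 cm/s. Compound 3, `O=C(N[C@H]1CN(S(=O)(=O)c2ccccc2)C[C@@H]1C(=O)N[C@H]1CCCNC1)c1cc(-c2ccc(Cl)cc2Cl)on1`, departs from compound 2 by chloro in place of hydrogen on an aromatic carbon, turning 2-chlorophenyl into 2,4-dichlorophenyl. Going by the values given here, one measured step bears on this change: 2-chlorophenyl in place of 4-chlorophenyl gave an at least 31-fold higher number from compound 1 to compound 2 (1.49 log units; beyond the scatter), which is large and beyond the scatter. The size of that step is bounded by the limit of < 0.01 10^-6 cm/s in this assay, at which 1 of the 2 values shown sits. Compound 3 carries the chloro groups of both compounds, so a lower number than that of compound 2 is expected, probably beyond the scatter but smaller than the measured step. The expected change is a 3.9-fold lower number from compound 2 to compound 3 (0.59 log units; beyond the scatter). Compound 3 is estimated at 0.08 10^-6 cm/s, with an expected range of 0.01 10^-6 cm/s to 0.4 10^-6 cm/s.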

Compound 3, apparent permeability: < 0.07 10^-6 cm/s
Compound 3: only a limit was reported; the forecaster's own chance of this, stated with the estimate: 30%; middle value at least 1.1-fold (0.05 log units) away from the limit.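

In this assay, turning 2-chlorophenyl into 2,4-dichlorophenyl gives an at least 4.4-fold lower number from compound 2 to compound 3 (0.64 log units; beyond the scatter). The earlier pair showed only a chloro moved from one place to another; this step shows that the number of compound 2 does not hold once a chloro is added para to a large group while the first chloro stays in place. Compound 3 gives only a limit of the assay, and the step from compound 1 to compound 3 cannot be read because both ends of it are limits: the limit of < 0.07 10^-6 cm/s in this assay, at which 1 of the 3 values shown sits.

The compounds shown leave open whether a group other than chloro at this place, such as fluoro, methoxy or an amine, would give a readable number in this assay. They also leave open how far under its limit compound 3 lies.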